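Swapping a tert-Butyl Amide for a Fluorophenyl Amide

The source may report more compounds than this note shows. Statements on the series, on what has been measured and on what is new or still open speak of the compounds shown alone.

Compound 1, `COc1ccc(S(=O)(=O)N2CCc3cccc(NC(=O)C(C)(C)C)c32)cc1`: in a functional assay on KB cells (Homo sapiens) for cytotoxicity (on this read-out lower numbers stand for stronger inhibition and higher numbers for weaker inhibition), compound 1 gives 359 nM.
Compound 2, `COc1ccc(S(=O)(=O)N2CCc3cccc(NS(=O)(=O)c4ccc(F)cc4)c32)cc1`: compound 2 gives 1200 nM.
Compound 3, `COc1ccc(S(=O)(=O)N2CCc3cccc(NC(=O)Oc4ccccc4)c32)cc1`: compound 3 gives > 10000 nM, which is a limit of the assay rather than a number.

Compound 1 has the lowest of the two numbers measured; its nearest neighbour is compound 2, with a 3.3-fold higher number from compound 1 to compound 2 (0.52 log units; beyond the scatter). Compound 3 sits at the limit of > 10000 nM in this assay, at which 1 of the 3 values shown sits. The compound still to be measured is compound 4, `COc1ccc(S(=O)(=O)N2CCc3cccc(NC(=O)c4ccc(F)cc4)c32)cc1`. Relative to compound 1 it carries 4-fluorophenyl in place of tert-butyl on a carbonyl carbon. For the measured compounds named here, two measured steps bear on this change. Putting (4-fluorophenyl)sulfonyl in place of (tert-butyl)carbonyl on the nitrogen on the aromatic ring, which already introduces the 4-fluorophenyl ring, gave a modest loss. Putting phenoxy in place of tert-butyl on the carbonyl carbon gave an at least 27-fold higher number from compound 1 to compound 3 (1.44 log units; beyond the scatter). Both changes at this position weakened inhibition, the ring-bearing one only modestly. A modest rise in the number is therefore expected for compound 4, a 2.2-fold higher number from compound 1 to compound 4 (0.35 log units; beyond the scatter). The estimate for compound 4 is 800 nM, with a range from 300 nM to 2500 nM.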

Compound 4, half-maximal inhibitory concentration: 93 nM
The estimate for compound 4 lay 8.6-fold (0.93 log units) above the measured number; measured number outside the range, below it.
By their numbers in this assay, from the lowest: compound 4; then compound 1; then compound 2. At a limit, above all of these: compound 3.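

In this assay, the carbonyl carbon of this amide accepts an aromatic ring: 4-fluorophenyl in place of tert-butyl gives a 3.9-fold lower number from compound 1 to compound 4 (0.59 log units; beyond the scatter), the only change shown at this position that lowers the number. What joins the ring to the nitrogen also matters, for with the 4-fluorophenyl ring kept, carbonyl in place of sulfonyl gives a 13-fold lower number from compound 2 to compound 4 (1.11 log units; beyond the scatter). On the same carbonyl carbon, 4-fluorophenyl in place of phenoxy gives an at least 100-fold lower number from compound 3 to compound 4 (2.03 log units; beyond the scatter), a step that rests on a limit for compound 3 rather than on a number: the limit of > 10000 nM in this assay, at which 1 of the 4 values shown sits.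

The compounds shown leave open what the fluorine adds, a question that a plain phenyl on this carbonyl carbon would answer. They also leave open whether the ring must be aromatic, which a cyclohexyl group would test, and whether a pyridine ring would serve as well.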